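Benzyloxy in place of methoxy on the open-chain series

The source may hold more compounds than are shown below. What is called first, only, known or untested is meant among the compounds shown, and "the series" means these compounds.

In an assay on membranes from HEK293 cells for displacement of a labelled ligand from Translocator protein (Homo sapiens), read by scintillation counting, with a stated time of 90 min (on this read-out higher numbers stand for weaker inhibition and lower numbers for stronger inhibition), compound 1 `CCN(CC)C(=O)Cn1c(-c2ccc(OC)cc2)cc2c(C)cc(C)cc21` gives 114 nM. In this assay compound 2 `COc1ccc(CN(C(C)=O)c2cc(C)cc(C)c2)cc1` gives 500 nM, and compound 3 `CCN(CC)C(=O)CN(Cc1ccc(OC)cc1)c1cc(C)cc(C)c1` gives 1200 nM. Compound 3 therefore carries the highest of the three numbers: compound 2 is nearest to it, compound 1 furthest, both with lower numbers. Going by the values given here, the only single-point step among the measured compounds, a 2.4-fold higher number from compound 2 to compound 3 (0.38 log units; beyond the scatter), is a modest one and concerns the group on a nitrogen on an aromatic ring.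

Compound 4 `CCN(CC)C(=O)CN(Cc1ccc(OCc2ccccc2)cc1)c1cc(C)cc(C)c1` differs from compound 3 by phenyl in place of hydrogen on a saturated chain carbon bound to an oxygen on an aromatic ring, that is methoxy becoming benzyloxy. Among the compounds with values here, no measured step touches this part of the molecule: compounds 1, 2 and 3 all keep the methoxy group unchanged, and a 2.4-fold higher number from compound 2 to compound 3 (0.38 log units; beyond the scatter) alters a different site, so it gives no direction for the present change. The expectation rests on structural continuity alone, with compound 3 as the anchor. For compound 4 the expected step of a 1.2-fold lower number from compound 3 to compound 4 (0.08 log units; within the scatter) is none beyond the scatter, with a wide range to reflect the absence of any bearing comparison. Compound 4 is estimated at 1000 nM in this assay, between 250 nM and 4000 nM.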

Compound 4, inhibition constant: 433 nM
The estimate for compound 4 lay 2.3-fold (0.36 log units) above the measured number; the range from low to high includes it.
By their numbers in this assay, from the lowest: compound 1; then compounds 4 and 2 (each within the scatter of the next); then compound 3.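

In this assay, the site on a saturated chain carbon bound to an oxygen on an aromatic ring gives its first reading, a 2.8-fold lower number from compound 3 to compound 4 (0.44 log units; beyond the scatter), so methoxy to benzyloxy goes with modestly stronger inhibition and this position accepts the added phenyl without loss. Going by these compounds alone, the earlier compounds all kept methoxy fixed, and their only step, a 2.4-fold higher number from compound 2 to compound 3 (0.38 log units; beyond the scatter), concerned the group on the nitrogen and ran towards weaker inhibition; this position is therefore a second site in the open-chain series that responds to change, and here the number falls. No supporting data are available to account for the step, which stands as an observation on this single pair.

Still open, going by these compounds, is whether the gain needs the phenyl ring itself or only a larger group on the oxygen, a question that ethoxy, isopropoxy or 2-phenylethoxy on the same scaffold would address. Also open, on these data alone, is whether benzyloxy gives a step of similar direction and size with acetyl on the nitrogen, as in compound 2, or on the core of compound 1.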